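Fluoro for Ethyl on a Carboxy-Bearing Core

The source may hold more compounds than are shown below. What is called first, only, known or untested is meant among the compounds shown, and "the series" means these compounds.

Three compounds have been measured in a functional assay on A-375 cells (Homo sapiens) for antiproliferative activity, read by MTT assay, with a stated time of 24 h, tested at 0.41 ug/mL; a higher number here means a stronger effect of the compound at the concentration tested, a lower number a weaker effect:

Compound 1, `CCc1ccc2nc(C(=O)Nc3c(F)cc(-c4cccc(F)c4)cc3F)c(C)c(O)c2c1`: 3.56%
Compound 2, `Cc1c(C(=O)Nc2c(F)cc(-c3cccc(F)c3)cc2F)nc2ccc(F)cc2c1O`: 0.86%
Compound 3, `CCc1ccc2nc(C(=O)Nc3c(F)cc(-c4cccc(F)c4)cc3F)c(C)c(C(=O)O)c2c1`: 6.13%

Compound 1 and compound 2 differ in one place: fluoro in place of ethyl on an aromatic carbon. In this assay the step of a number 2.7 percentage points lower from compound 1 to compound 2 (within the scatter). Compound 3 carries a different core than compound 1, and that difference is carboxy in place of hydroxy on an aromatic carbon; here the step of a number 2.6 percentage points higher from compound 1 to compound 3 (within the scatter). Compound 3 stands highest of the three numbers, but both of its gaps, to compound 1 and to compound 2, lie within the scatter, so no order among the three can be read from these values.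

Compound 4, `Cc1c(C(=O)Nc2c(F)cc(-c3cccc(F)c3)cc2F)nc2ccc(F)cc2c1C(=O)O`, has not yet been measured. It differs from compound 3 by fluoro in place of ethyl on an aromatic carbon. This is the same change as that from compound 1 to compound 2: the group that leaves, the group that enters and the place around it are the same in both cases. The only thing that separates the two pairs is the core, which differs as described above for compound 1 and compound 3.

Going by the values given here, the expectation for compound 4 therefore rests on the one earlier instance of this change. Because the step of a number 2.7 percentage points lower from compound 1 to compound 2 (within the scatter) stayed within the scatter, the step from compound 3 to compound 4 is expected to be of similar size, about a number 2.6 percentage points lower from compound 3 to compound 4 (within the scatter). Compound 4 is estimated to give 3.5% in this assay, with a likely range from -3% to 10%.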

Compound 4, a percentage reported as inhibition, at one concentration (the size of the read-out at that concentration, not a potency): 3.02%
The estimate for compound 4 lay 0.5 percentage points above the measured number, within the range that was stated.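

In this assay, fluoro in place of ethyl on the carboxy-bearing core gave a number 3.1 percentage points lower from compound 3 to compound 4 (within the scatter), and this step agrees with the one seen on the hydroxy-bearing core: the same change on two cores in this assay, a number 2.7 percentage points lower (within the scatter) from compound 1 to compound 2 and a number 3.1 percentage points lower (within the scatter) from compound 3 to compound 4, 0.4 percentage points apart, within the scatter of two such steps. Carboxy in place of hydroxy, read on the pair that carries fluoro, gave a number 2.2 percentage points higher from compound 2 to compound 4 (within the scatter), and this step likewise agrees with its earlier instance: the same change on two cores in this assay, a number 2.6 percentage points higher (within the scatter) from compound 1 to compound 3 and a number 2.2 percentage points higher (within the scatter) from compound 2 to compound 4, 0.4 percentage points apart, within the scatter of two such steps. Across these four compounds, then, neither change shows a dependence on the core, but every step lies within the scatter, so the agreement shows only that no effect of either change can be told apart at this single tested concentration, not that the two changes have real effects of equal size on both cores.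

The compounds shown leave open whether another group at the place of the ethyl, such as chloro, methoxy, an amine or a longer chain, would give a step beyond the scatter. They also leave open how an ester or an amide in place of the carboxy would read, and whether any such step would carry from one core to the other.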